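This account rests on a few compounds, and the source may have more. Where it says the series, first, only, none or still open, it means among the compounds named here.

Series notes. Compound 1 `COc1ccc(/C=C/C2CC(=O)C=CO2)cc1` and compound 2 `COc1ccc(/C=C/C2CC(=O)C=CO2)cc1OC` share one core; compound 3 `COc1ccc(/C=C/C2CC=CC(=O)O2)cc1` and compound 4 `COc1ccc(/C=C/C2CC=CC(=O)O2)cc1OC` share another. In a functional assay on NCI/ADR cells (Homo sapiens) for inhibition, read by sulforhodamine B assay, with a stated time of 48 h (on this read-out lower numbers stand for stronger inhibition of growth and higher numbers for weaker inhibition of growth), compound 1 gives 239 uM, and compound 2 gives 146 uM. The change between them is methoxy in place of hydrogen on an aromatic carbon, and the step it made, a 1.6-fold lower number from compound 1 to compound 2 (0.21 log units; within the scatter), is small. How the core of compound 3 differs from the core of compound 1 is not broken down here; the two have the same atoms joined differently. In this assay compound 3 gives 17.3 uM, the lowest number of the three measured compounds, with compound 2 and compound 1 both beyond the scatter from it.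

Compound 4 carries the same change relative to compound 3: methoxy in place of hydrogen on an aromatic carbon. The surroundings of the place are the same in both pairs. Because the earlier step of a 1.6-fold lower number from compound 1 to compound 2 (0.21 log units; within the scatter) lay within the scatter, the expectation for compound 4 in this assay is a step of similar size, a 1.4-fold lower number from compound 3 to compound 4 (0.16 log units; within the scatter). That expectation rests on compound 3 at 17.3 uM and on the earlier pair alone. Compound 4 is accordingly estimated at 12 uM, expected between 5 uM and 35 uM. The measurement will show whether this holds.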

Compound 4, concentration for growth inhibition (reported as GI): 11.6 uM
Estimate against measurement, compound 4: 1.0-fold (0.01 log units) above; low and high end bracket the measured number.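

In this assay, methoxy in place of hydrogen on an aromatic carbon gave a 1.5-fold lower number from compound 3 to compound 4 (0.17 log units; within the scatter), and the step on this core reads the same as the earlier one: the same change on two cores in this assay, a 1.6-fold lower number (0.21 log units; within the scatter) from compound 1 to compound 2 and a 1.5-fold lower number (0.17 log units; within the scatter) from compound 3 to compound 4, 1.1-fold (0.04 log units) apart, within the scatter of two such steps

For this one change, then, the size of the step carried over between the two cores with no visible difference. Both steps lie within the scatter, so neither pair shows that the methoxy alters growth inhibition at all, and the agreement between two small steps on two cores says nothing about how a change with a larger step would carry over.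

Still open, going by these compounds, is whether an amine, a carboxylic acid or a longer alkoxy chain in place of the methoxy would give a step beyond the scatter, and whether such a step would match on both cores. Also open, on these data alone, is how the same methoxy change would behave at another carbon of the aromatic ring.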